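Swapping furan-2-yl for thiophen-3-yl on the shared core

The source may hold more compounds than are shown below. What is called first, only, known or untested is meant among the compounds shown, and "the series" means these compounds.

Measured so far, in an assay on membranes from HeLa cells for displacement of a labelled ligand from adenosine receptor A3 (Homo sapiens), read by scintillation counting, with a stated time of 180 min, tested at 1 uM; on this read-out lower numbers stand for less inhibition and higher numbers for more inhibition at the one concentration tested (going by the name of the read-out):
Compound 1 `CC1=C(C(=O)OC(C)(C)C)C(c2ccsc2)NC(=O)N1`: 1%
Compound 2 `CC1=C(C(=O)C2CC2)C(c2ccsc2)NC(=O)N1`: 1%
Compound 3 `CCSC(=O)C1=C(C)NC(=O)NC1c1ccco1`: 14%

Compound 3 gives the highest of the three numbers in this assay; compound 1 and compound 2 both sit lower by a gap beyond the scatter. Compound 4 `CCSC(=O)C1=C(C)NC(=O)NC1c1ccsc1` differs from compound 3 in one place: thiophen-3-yl in place of furan-2-yl on a saturated ring carbon. For the measured compounds named here, the only measured step, no change at the digits printed from compound 1 to compound 2 (within the scatter), concerns a carbonyl substituent, not the ring swapped here, so it does not bear directly on this change. Compound 1 and compound 2, which carry thiophen-3-yl, show low values, whereas compound 3 with furan-2-yl shows a higher one, but those pairs differ in two places. Compound 4 is therefore expected to fall somewhat, by a number 8 percentage points lower from compound 3 to compound 4 (within the scatter), to an estimated 6% within 0% to 18%.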

Compound 4, a percentage reported as inhibition, at one concentration (the size of the read-out at that concentration, not a potency): 2%
Compound 4: the middle estimate sits 4 percentage points above what was measured; low and high end bracket the measured number.
By their numbers in this assay, from the lowest: compounds 1, 2 and 4 (each within the scatter of the next); then compound 3.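

In this assay, for the compounds shown here, with the ethylsulfanyl carbonyl group held constant, thiophen-3-yl in place of furan-2-yl gives a number 12 percentage points lower from compound 3 to compound 4 (beyond the scatter), the first reading of this ring swap on its own. With thiophen-3-yl present, changing the carbonyl substituent shows little: ethylsulfanyl in place of cyclopropyl gives a number 1 percentage points higher from compound 2 to compound 4 (within the scatter), and ethylsulfanyl in place of tert-butoxy gives a number 1 percentage points higher from compound 1 to compound 4 (within the scatter). No measurement here explains the drop from the ring swap.

From the compounds shown here alone, it remains open how a phenyl ring on the saturated ring carbon would compare with furan-2-yl or thiophen-3-yl. Also open, going by these compounds, is whether tert-butoxy or cyclopropyl on the carbonyl would change the number when furan-2-yl is present.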